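One group exchanged on the shared core

A few compounds are considered here, and "the series" means these few. Any claim that something is new, unique, unknown or untested is made for them only; others in the source may bear on it.

Measured in a functional assay on HL-60 cells (Homo sapiens) for inhibition, read by CCK-8 assay, with a stated time of 48 h; on this read-out higher numbers stand for weaker inhibition and lower numbers for stronger inhibition:
Compound 1 `O=C(Nc1ccc(F)cc1)N1CCN(S(=O)(=O)c2sccc2-c2ccccc2Oc2ccc(O)c(O)c2)CC1`: 8100 nM
Compound 2 `O=C(Nc1ccc([N+](=O)[O-])cc1)N1CCN(S(=O)(=O)c2sccc2-c2ccccc2Oc2ccc(O)c(O)c2)CC1`: 4900 nM

Compound 2, at 4900 nM, lies within the scatter of compound 1, so the two cannot be ranked. Compound 3 `O=S(=O)(c1sccc1-c1ccccc1Oc1ccc(O)c(O)c1)N1CCN(C(=S)Nc2ccc(Cl)cc2)CC1` departs from compound 2 by one exchange: a group of 10 heavy atoms (7 carbon, 1 nitrogen, 1 sulfur, 1 chlorine; one six-membered aromatic ring of carbon only) in place of a group of 12 heavy atoms (7 carbon, 2 nitrogen, 3 oxygen; one six-membered aromatic ring of carbon only), on an amine nitrogen in a ring. For the measured compounds named here, only one measured step bears on this, a 1.7-fold lower number from compound 1 to compound 2 (0.22 log units; within the scatter), and it covers a smaller exchange than this one. Going by the values given here, no measured pair tests the whole group, so no step beyond the scatter is expected in this assay, though with wide uncertainty. The estimated change is a 1.2-fold higher number from compound 2 to compound 3 (0.09 log units; within the scatter). Compound 3 is expected at 6000 nM, with an estimated range of 2500 nM to 15000 nM.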

Compound 3, half-maximal inhibitory concentration: 5500 nM
For compound 3 the middle estimate is 1.1-fold (0.04 log units) above the measured one; low and high end bracket the measured number.
By their numbers in this assay, from the lowest: compounds 2, 3 and 1 (each within the scatter of the next).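

In this assay the exchange on the ring amine nitrogen gives a 1.1-fold higher number from compound 2 to compound 3 (0.05 log units; within the scatter) and a 1.5-fold lower number from compound 1 to compound 3 (0.17 log units; within the scatter) and both steps lie within the scatter. Neither the exchange of the (4-nitrophenyl)carbamoyl group nor the exchange of oxygen and fluorine for sulfur and chlorine in the group on that nitrogen separates the compounds at this position. For the compounds shown here, no evidence on the compounds bears on this result.

As far as these compounds go, it remains open whether an acetyl group or a longer alkyl chain on this nitrogen, with no aromatic ring, would move the number beyond the scatter. The same holds for a group carrying a carboxylic acid or an amine.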